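The source may hold more compounds than are shown below. What is called first, only, known or untested is meant among the compounds shown, and "the series" means these compounds.

Compound 2 `C=C(Br)C(=O)Nc1cccc(-c2cn3nc(-c4ccc(OC)cc4)sc3n2)c1` was tested in a functional assay on L1210 cells (Mus musculus) for inhibition, read by cell counting, with a stated time of 2 days (on this read-out lower numbers stand for stronger inhibition and higher numbers for weaker inhibition), and gives 940 nM. Among the two compounds measured it holds the highest number, so it is the weaker of the pair; its closest neighbour, compound 1 `C=C(Br)C(=O)Nc1cccc(-c2cn3nc(-c4ccc(OC)c(OC)c4)sc3n2)c1`, gives 42 nM. Within the data shown here, the one step that joins these two is a 22-fold higher number from compound 1 to compound 2 (1.35 log units; beyond the scatter), which shows how strongly the outcome moves when a methoxy group is lost from an aromatic ring.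

Compound 3 `C=C(Br)C(=O)Nc1cccc(-c2cn3nc(Cc4ccc(OC)cc4)sc3n2)c1` has not yet been measured. It is built from compound 2 by 4-methoxybenzyl in place of 4-methoxyphenyl on an aromatic carbon. Among the measured compounds shown here, no measured step covers a change of this kind: the only known step concerns a methoxy group and says nothing about placing a 4-methoxybenzyl group where a 4-methoxyphenyl group stood. The expectation for this assay rests on little, and compound 3 is estimated at 1500 nM, within a wide range from 300 nM to 8000 nM. The step this estimate means, a 1.6-fold higher number from compound 2 to compound 3 (0.20 log units; within the scatter), is expected to stay within the scatter, with large uncertainty in either direction.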

Compound 3, half-maximal inhibitory concentration: 1400 nM
The estimate for compound 3 lay 1.1-fold (0.03 log units) above the measured number, and the stated range covers the measured number.
By their numbers in this assay, from the lowest: compound 1; then compounds 2 and 3 (each within the scatter of the next).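

At this aromatic carbon, next to the ring nitrogen and the ring sulfur, swapping 4-methoxyphenyl for 4-methoxybenzyl gives in this assay a 1.5-fold higher number from compound 2 to compound 3 (0.17 log units; within the scatter) and so leaves the two compounds indistinguishable, which shows that this position tolerates the change when the ring carries a single methoxy group. The comparison with the dimethoxy compound gives a 33-fold higher number from compound 1 to compound 3 (1.52 log units; beyond the scatter) and is a large step, but it replaces 3,4-dimethoxyphenyl with 4-methoxybenzyl and so does not separate the loss of a methoxy group from the change in how the ring is attached; among these compounds, only compound 1 stands apart from the others. Nothing available here accounts for these numbers.

A 3,4-dimethoxybenzyl group at this position would show whether the second methoxy group has the same large effect on a benzyl group as on a phenyl group. As far as these compounds go, it also remains open how a longer chain, such as 2-(4-methoxyphenyl)ethyl, or an amine, such as morpholine, would behave at this carbon.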